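A few compounds are considered here, and "the series" means these few. Any claim that something is new, unique, unknown or untested is made for them only; others in the source may bear on it.

Measured so far in a functional assay on the whole organism (strain Albino) for inhibition, with Mus musculus as the target, in the writhing test, at a dose of 50 mg/kg by the oral route; on this read-out higher numbers stand for more inhibition at the one dose given (going by the name of the read-out) and lower numbers for less inhibition:
compound 1 `CCOC(=O)c1c(Nc2ccc(OC)cc2)ncnc1NC(C)C`: 85.1%
compound 2 `CCOC(=O)c1c(Nc2ccc([N+](=O)[O-])cc2)ncnc1NC(C)C`: 77.4%

Both measured compounds share a core that carries an ethyl ester and an isopropylamino group, and differ only in the group on the aromatic ring attached through the anilino nitrogen. In this assay compound 1 gives 85.1% and compound 2 gives 77.4%. For the measured compounds named here, the single step between them, a number 7.7 percentage points lower from compound 1 to compound 2 (within the scatter), lies within the scatter, so compound 2 stands alongside the only other number rather than apart from it.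

Compound 3 `CCOC(=O)c1c(Nc2ccc(S(N)(=O)=O)cc2)ncnc1NC(C)C` is not yet measured. It differs from compound 2 by sulfamoyl in place of nitro on an aromatic carbon. Going by the values given here, the one step that bears on this position, a number 7.7 percentage points lower from compound 1 to compound 2 (within the scatter), was small, and it concerned a different pair of groups, so the data give no direct guide for a sulfamoyl group. The expectation is therefore that the step of a number 1.6 percentage points higher from compound 2 to compound 3 (within the scatter) stays within the scatter. Compound 3 is thus expected to give about 79% in this assay, with a range from 60% to 93%.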

Compound 3, a percentage reported as inhibition, in the whole organism at one dose (the size of the read-out at that dose, not a potency): 72.6%
Beside the measured number, compound 3's estimate is 6.4 percentage points above it, within the range that was stated.
By their numbers in this assay, from the lowest: compounds 3, 2 and 1 (each within the scatter of the next, the first and the last beyond it).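

In this assay, sulfamoyl on an aromatic carbon para to a large group reads much like nitro at the same place, with a number 4.8 percentage points lower from compound 2 to compound 3 (within the scatter), so this exchange adds a larger group carrying a hydrogen-bond donor without a change that can be told from the scatter. The comparison with methoxy shows something the earlier pair did not: a number 12.5 percentage points lower from compound 1 to compound 3 (beyond the scatter), the only step among these three compounds that passes the scatter, so the group at this position can make a modest difference to the read-out, while nitro stays within the scatter of both other groups. Nothing measured here accounts for that difference between methoxy and sulfamoyl.

The compounds shown leave open how an amine, a carboxylic acid or a longer chain such as butoxy would read at this aromatic carbon, and so whether methoxy and sulfamoyl mark the limits of what this position allows. They also leave open how far the ethyl ester and the isopropylamino group of the shared core contribute, since both stay the same throughout.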